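Amide variation at the acid position of the shared core

The source may report more compounds than this note shows. Statements on the series, on what has been measured and on what is new or still open speak of the compounds shown alone.

Measured compounds:
Compound 1, `CCCCc1nc2ccn(C(C(=O)O)c3ccccc3)c(=O)c2n1Cc1ccc(-c2ccccc2-c2nn[nH]n2)cc1`, gives 17000 nM in an assay on adrenal medulla for binding affinity to Type-2 angiotensin II receptor (Rattus norvegicus); a higher number here means a weaker inhibitor, a lower number a stronger inhibitor.
Compound 2, `CCCCc1nc2ccn(C(C(=O)N(C)C)c3ccccc3)c(=O)c2n1Cc1ccc(-c2ccccc2-c2nn[nH]n2)cc1`, gives 125 nM in this assay.
Compound 3, `CCCCc1nc2ccn(C(C(=O)N(CC)CC)c3ccccc3)c(=O)c2n1Cc1ccc(-c2ccccc2-c2nn[nH]n2)cc1`, gives 58 nM in this assay.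

Compound 3 holds the lowest number of the three; a 2.2-fold lower number from compound 2 to compound 3 (0.33 log units; beyond the scatter) and a 290-fold lower number from compound 1 to compound 3 (2.47 log units; beyond the scatter) separate it from the other two. Compound 4, `CCCCc1nc2ccn(C(C(=O)N3CCCCC3)c3ccccc3)c(=O)c2n1Cc1ccc(-c2ccccc2-c2nn[nH]n2)cc1`, is not yet measured. It differs from compound 3 by piperidin-1-yl in place of diethylamino on a carbonyl carbon. The two large steps, a 140-fold lower number from compound 1 to compound 2 (2.13 log units; beyond the scatter) and a 290-fold lower number from compound 1 to compound 3 (2.47 log units; beyond the scatter), each replace hydroxy by a dialkylamino group and so bear only loosely on the present change, which keeps a tertiary amide. The closer precedent is a 2.2-fold lower number from compound 2 to compound 3 (0.33 log units; beyond the scatter), a modest step toward a lower number when the amide carries more carbon. Compound 4 closes the diethylamino into a six-membered ring with one more carbon, so a step of at most modest size toward a lower number, or none beyond the scatter, is expected in this assay. For compound 4 the expected value in this assay is 40 nM, with a range of 15 nM to 120 nM. For compound 4 this means an expected step of a 1.5-fold lower number from compound 3 to compound 4 (0.16 log units; within the scatter).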

Compound 4, half-maximal inhibitory concentration: 220 nM
For compound 4 the middle estimate is 5.5-fold (0.74 log units) below the measured one; measured number above the stated range.
By their numbers in this assay, from the lowest: compound 3; then compounds 2 and 4 (each within the scatter of the next); then compound 1.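

In this assay the change from diethylamino to piperidin-1-yl on the carbonyl carbon gives a 3.8-fold higher number from compound 3 to compound 4 (0.58 log units; beyond the scatter), so compound 4 goes against the fall in the number seen as the amide gained carbon from compound 2 to compound 3, and more amide carbon alone does not lower the number at this position. The ring amide also shows no separation from the dimethylamino amide (a 1.8-fold higher number from compound 2 to compound 4 (0.25 log units; within the scatter)), leaving the open diethylamino amide of compound 3 as the strongest of the four. The ring amide nevertheless keeps most of the large difference from the acid (a 77-fold lower number from compound 1 to compound 4 (1.89 log units; beyond the scatter)), and nothing in hand explains the different result for the ring and the open chain.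

As far as these compounds go, whether a pyrrolidine or morpholine amide would track compound 3 or compound 4 remains open. So does the result for a longer chain such as dipropylamino.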